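Extending the Group on the Amide-Type Nitrogen

The compounds below may be only part of what the source reports. "The series", "measured", "known", "first", "only" and "open" are said of these compounds alone.

- compound 1 `COc1cc2c(Oc3ccc(NC(=O)Nc4ccccc4F)cc3)ccnc2cc1OCCCCCCC(=O)NO`: 660 nM
- compound 2 `COc1cc2c(Oc3ccc(NC(=O)NC4CCCCC4)cc3)ccnc2cc1OCCCCCCC(=O)NO`: 600 nM
- compound 3 `COc1cc2c(Oc3ccc(NC(=O)N/N=C/c4ccccc4F)cc3)ccnc2cc1OCCCCCCC(=O)NO`: 1610 nM

In a functional assay on MCF7 cells (Homo sapiens) for antiproliferative activity, read by MTT assay (a lower number here means a stronger inhibitor, a higher number a weaker inhibitor), compound 1 gives 660 nM, and the step to its nearest neighbour is a 1.1-fold lower number from compound 1 to compound 2 (0.04 log units; within the scatter). Compound 4 `COc1cc2c(Oc3ccc(NC(=O)NNC(=O)c4ccccc4)cc3)ccnc2cc1OCCCCCCC(=O)NO` carries benzamido in place of 2-fluorophenyl on an amide-type nitrogen. The closest guide is the step that also brings in a larger group containing a nitrogen, a 2.4-fold higher number from compound 1 to compound 3 (0.39 log units; beyond the scatter). The matching step from the cyclohexyl compound is a 2.7-fold higher number from compound 2 to compound 3 (0.43 log units; beyond the scatter). Within the data shown here, no measured compound carries benzamido, so the range stays wide. A similar modest rise is expected, an estimated 2.0-fold higher number from compound 1 to compound 4 (0.29 log units; within the scatter). For compound 4 the estimated value is 1300 nM, with an expected range of 550 nM to 3000 nM.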

Compound 4, half-maximal inhibitory concentration: 2450 nM
Estimate against measurement, compound 4: 1.9-fold (0.28 log units) below; the range from low to high includes it.
By their numbers in this assay, from the lowest: compounds 2 and 1 (each within the scatter of the next); then compounds 3 and 4 (each within the scatter of the next).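

In this assay, benzamido on this amide-type nitrogen gives a weaker result than either smaller group, with a 3.7-fold higher number from compound 1 to compound 4 (0.57 log units; beyond the scatter) and a 4.1-fold higher number from compound 2 to compound 4 (0.61 log units; beyond the scatter). The other group that extends this position through an added nitrogen behaves alike, with a 1.5-fold higher number from compound 3 to compound 4 (0.18 log units; within the scatter), so among these four compounds both extended groups sit on the weaker side. No measured evidence explains this. The compounds shown leave open whether the added nitrogen or the distant phenyl ring goes with the weaker result; a simple amino group or a benzyl group at this position could help separate the two.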